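The source may report more compounds than this note shows. Statements on the series, on what has been measured and on what is new or still open speak of the compounds shown alone.

Compound 1 `Fc1ccc2c(c1)/C(=N\OCc1ccccc1)C(c1c[nH]c3ccc(F)cc13)=N2` gives 12500 nM in a functional assay on T-24 cells (Homo sapiens) for cytotoxicity, read by MTT assay, with a stated time of 2 days; a higher number here means a weaker inhibitor, a lower number a stronger inhibitor. Among the measured compounds shown here, of the two numbers measured so far, that of compound 1 is the lowest; compound 2 `Cc1ccc(CO/N=C2/C(c3c[nH]c4ccccc34)=Nc3ccccc32)cc1` gives 23500 nM in this assay, and the gap between the two lies within the scatter, so no order between them is claimed. Compound 3 `Cc1ccc(CO/N=C2/C(c3c[nH]c4ccc(F)cc34)=Nc3ccc(F)cc32)cc1` has not yet been measured in this assay. It differs from compound 1 in one place: methyl in place of hydrogen on an aromatic carbon. Compound 2 carries the same methyl while lacking the two fluorine atoms shared by compound 1 and compound 3, and its number sits close to that of compound 1. For the measured compounds named here, no step between measured compounds covers this change on the fluorinated core, and nothing among the numbers points to a shift beyond the scatter in either direction. The step expected is a 1.2-fold higher number from compound 1 to compound 3 (0.08 log units; within the scatter), close to none. Compound 3 is estimated at 15000 nM in this assay, with a range from 6000 nM to 40000 nM.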

Compound 3, half-maximal inhibitory concentration: 20000 nM
Estimate against measurement, compound 3: 1.3-fold (0.12 log units) below; the measured number falls inside the stated range.
By their numbers in this assay, from the lowest: compounds 1, 3 and 2 (each within the scatter of the next).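

In this assay, the change from benzyl to 4-methylbenzyl on the fluorinated core gives a 1.6-fold higher number from compound 1 to compound 3 (0.20 log units; within the scatter) and so sets no order between the two compounds. Among the compounds shown here, this is the first direct reading of the methyl: with only the methyl changed, this aromatic carbon of the benzyl group accepts it without a shift that can be told from the scatter. No measurement available here bears on the reason for a step of this size.

As far as these compounds go, whether a methoxy, an amine or a carboxylic acid at the same carbon would move the number beyond the scatter remains open. The compounds shown also give no single-place step for either fluorine atom, so the separate contribution of each to the number stays unresolved.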